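A few compounds are considered here, and "the series" means these few. Any claim that something is new, unique, unknown or untested is made for them only; others in the source may bear on it.

Three compounds share a common core and differ only in the group attached to the carbonyl carbon on the ring nitrogen. Compound 1 `CCOC(=O)/C=C/C(=O)N(CC(N)=O)NC(=O)[C@@H]1CCCN1C(=O)[C@H]1CSCN1C(C)=O` gives 167 nM in an assay on isolated protein for inhibition of legumain (Mus musculus), read by fluorescence, with stated times of 30 s and 2.5 h; a higher number here means a weaker inhibitor, a lower number a stronger inhibitor. Compound 2 `CCOC(=O)/C=C/C(=O)N(CC(N)=O)NC(=O)[C@@H]1CCCN1C(=O)C(C)(C)NC(C)=O` gives 198 nM in this assay, and compound 3 `CCOC(=O)/C=C/C(=O)N(CC(N)=O)NC(=O)[C@@H]1CCCN1C(=O)c1ccc(CNC(C)=O)cc1` gives 267 nM in this assay. Going by the values given here, compound 3 carries the highest of the three numbers, yet no step separates it from the others beyond the scatter: the step of a 1.6-fold higher number from compound 1 to compound 3 (0.20 log units; within the scatter) and the step of a 1.3-fold higher number from compound 2 to compound 3 (0.13 log units; within the scatter) are both small, as is the step of a 1.2-fold higher number from compound 1 to compound 2 (0.07 log units; within the scatter). Across these three, swapping a five-membered ring, an open chain and an aromatic ring at this position has left the numbers essentially unchanged.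

Compound 4 `CCOC(=O)/C=C/C(=O)N(CC(N)=O)NC(=O)[C@@H]1CCCN1C(=O)c1cccc(NC(C)=O)c1` is the next variation at the same place. The change is 3-acetamidophenyl in place of 4-(acetamidomethyl)phenyl on a carbonyl carbon. Among the compounds with values here, the steps that bear on it are those ending at compound 3, and each of them lay within the scatter. Another change of the same kind at this position is therefore expected to give a step of no more than the scatter in this assay, in no particular direction. Compound 4 is expected to give about 260 nM in this assay, between 120 nM and 560 nM, which is the expected step of a 1.0-fold lower number from compound 3 to compound 4 (0.01 log units; within the scatter).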

Compound 4, half-maximal inhibitory concentration: > 1000 nM
Compound 4 ended at the assay's limit; the forecaster's own chance of this, stated with the estimate: 2%; middle value at least 3.8-fold (0.58 log units) away from the limit.
By their numbers in this assay, from the lowest: compounds 1, 2 and 3 (each within the scatter of the next). At a limit, above all of these: compound 4.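

The position on the carbonyl carbon had shown no clear preference among a five-membered ring, an open chain and an aromatic ring in this assay, but it does not accept every group alike: 3-acetamidophenyl in place of 4-(acetamidomethyl)phenyl gives an at least 3.7-fold higher number from compound 3 to compound 4 (0.57 log units; beyond the scatter), and the same group measured against the other two gives an at least 5.0-fold higher number from compound 2 to compound 4 (0.70 log units; beyond the scatter) and an at least 5.9-fold higher number from compound 1 to compound 4 (0.77 log units; beyond the scatter). The two aromatic groups carry the same kind of ring and the same counts of hydrogen-bond donors and acceptors, so those counts do not separate compound 3 from compound 4. The reading for compound 4 is a limit of the assay and not a number: the limit of > 1000 nM in this assay, at which 1 of the 4 values shown sits.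

The compounds shown leave open whether the loss follows the place of the substituent on the aromatic ring or the length of the link to the acetamide, a question that 4-acetamidophenyl or 3-(acetamidomethyl)phenyl on the same carbonyl carbon would address. Going by these compounds, whether 3-aminophenyl or 3-carboxyphenyl at this position would behave like 3-acetamidophenyl is equally open.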